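A few compounds are considered here, and "the series" means these few. Any claim that something is new, unique, unknown or untested is made for them only; others in the source may bear on it.

Measured so far:
compound 1 `Cc1ccc(S(=O)(=O)/N=C(/CCNC2=CC(=O)c3ccccc3C2=O)Nc2cccc(C(F)(F)F)c2)cc1` — 89100 nM
compound 2 `Cc1ccc(S(=O)(=O)/N=C(/CCNC2=CC(=O)c3ccccc3C2=O)Nc2ccc(Cl)cc2Cl)cc1` — 17000 nM

Both numbers come from a functional assay on MCF7 cells (Homo sapiens) for cytotoxicity, read by MTT assay, with a stated time of 48 h; on this read-out lower numbers stand for stronger inhibition and higher numbers for weaker inhibition. Within the data shown here, compound 2 holds the lower of the two numbers; its only neighbour is compound 1, and the step of a 5.2-fold lower number from compound 1 to compound 2 (0.72 log units; beyond the scatter) lies beyond the scatter, so the group on the amine nitrogen plainly moves this read-out. Compound 3 `Cc1ccc(S(=O)(=O)/N=C(/CCNC2=CC(=O)c3ccccc3C2=O)NCc2ccccc2)cc1` has not been measured. It differs from compound 2 by benzyl in place of 2,4-dichlorophenyl on an amine nitrogen. Among the measured compounds shown here, the one measured step, a 5.2-fold lower number from compound 1 to compound 2 (0.72 log units; beyond the scatter), concerns the same amine nitrogen but exchanges one aryl group for another; no measured step exchanges an aryl group for a benzyl group, so the direction of the change can only be read loosely from that step. Because compound 1 gives 89100 nM, a move away from the 2,4-dichlorophenyl of compound 2 is expected to give a higher number rather than a lower one, with wide uncertainty. For compound 3 the step is expected to be a 3.5-fold higher number from compound 2 to compound 3 (0.55 log units; beyond the scatter). For compound 3 the estimate in this assay is 60000 nM, with a range from 15000 nM to 250000 nM.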

Compound 3, half-maximal inhibitory concentration: 3630 nM
Compound 3: middle estimate off by 17-fold (1.22 log units), on the high side; the whole stated range lies above it.
By their numbers in this assay, from the lowest: compound 3; then compound 2; then compound 1.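

Within this assay, moving from a halogen-bearing aryl group to benzyl on the amine nitrogen gives a 4.7-fold lower number from compound 2 to compound 3 (0.67 log units; beyond the scatter) and takes the series to its lowest number so far. Against the 3-(trifluoromethyl)phenyl group, the same kind of exchange gives a 25-fold lower number from compound 1 to compound 3 (1.39 log units; beyond the scatter), the largest step in the set, so compound 3 is the most potent of the three on this read-out and the amine nitrogen is not limited to a directly attached substituted phenyl ring. No measured evidence shown here accounts for either step.

Benzyl differs from 2,4-dichlorophenyl both in its methylene spacer and in its ring without chlorine, and the compounds shown change these two features together, so it remains open which of them goes with the lower number. A plain phenyl, a 2,4-dichlorobenzyl or a longer 2-phenylethyl chain on the same nitrogen would pull these features apart, and a cyclohexylmethyl group would test whether the aromatic ring is needed at all.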